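Fluorophenyl for dichlorophenyl carried onto the second core

This account rests on a few compounds, and the source may have more. Where it says the series, first, only, none or still open, it means among the compounds named here.

Compound 1 `O=S(=O)(/C=C/c1ccc(F)cc1)Cc1ccc(Nc2ncnc3ccccc23)cc1` and compound 2 `O=S(=O)(/C=C/c1ccc(Cl)cc1Cl)Cc1ccc(Nc2ncnc3ccccc23)cc1` share one core and differ only in the aryl group on the chain. In a functional assay on ACHN cells (Homo sapiens) (a lower number here means a stronger inhibitor of growth, a higher number a weaker inhibitor of growth), compound 1 gives 10 nM, and compound 2 gives 100 nM. The step of a 10-fold lower number from compound 2 to compound 1 (1.00 log units; beyond the scatter) corresponds to the change (4-fluorophenyl in place of 2,4-dichlorophenyl on a double-bonded chain carbon bound to a double-bonded chain carbon). Compound 3 `COc1cc2ncnc(Nc3ccc(CS(=O)(=O)/C=C/c4ccc(Cl)cc4Cl)cc3)c2cc1OC` carries the same 2,4-dichlorophenyl chain on a different core; in this assay compound 3 gives 15000 nM, the highest number of the three measured. The difference between the core of compound 2 and the core of compound 3 is not broken down here. Compound 4 `COc1cc2ncnc(Nc3ccc(CS(=O)(=O)/C=C/c4ccc(F)cc4)cc3)c2cc1OC` is the not yet measured partner of compound 3 and relates to it as compound 1 relates to compound 2: the change is 4-fluorophenyl in place of 2,4-dichlorophenyl on a double-bonded chain carbon bound to a double-bonded chain carbon, made at the same place, so it is the same change. Going by the values given here, whether a step of this size carries over from the core of compound 2 to the core of compound 3 is not known; the pair of compounds 2 and 3 shows only that the second core gives a far higher number with the dichlorophenyl chain. Among the compounds with values here, for compound 4 a step of about a 10-fold lower number from compound 3 to compound 4 (1.00 log units; beyond the scatter) is expected, close to the earlier step, because a 10-fold lower number from compound 2 to compound 1 (1.00 log units; beyond the scatter) is the only precedent for this change. Compound 4 is thus estimated at 1500 nM in this assay, with a range of 300 nM to 8000 nM to allow for the core difference.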

Compound 4, concentration for 50% growth inhibition: > 100000 nM
Compound 4 gave a limit, no number (the forecaster's own chance of this, stated with the estimate: 10%); middle value at least 66-fold (1.82 log units) from the limit.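

In this assay compound 4 gives > 100000 nM, which is a limit of the assay and not a number. The 4-fluorophenyl for 2,4-dichlorophenyl change therefore does not carry over between these two cores, since the step on the second core, an at least 6.6-fold higher number from compound 3 to compound 4 (0.82 log units; beyond the scatter), runs opposite to a 10-fold lower number from compound 2 to compound 1 (1.00 log units; beyond the scatter) on the first, and the two steps differ clearly: the same change on two cores in this assay, a 10-fold lower number (1.00 log units; beyond the scatter) from compound 2 to compound 1 and an at least 6.6-fold higher number (0.82 log units; beyond the scatter) from compound 3 to compound 4, at least 66-fold (1.82 log units) apart, beyond the scatter of two such steps This shows that, in this series, the outcome of the change depends on the core it is made on, but it rests on one pair per core, gives no true size for the step on the second core, and does not show what causes the reversal.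

Open, from the compounds shown here alone, is how a 4-chlorophenyl or an unsubstituted phenyl in the same place would read on each core, which would separate gaining the fluorine from losing each chlorine. Also open, going by these compounds, is which part of the difference between the core of compound 2 and the core of compound 3 goes with the reversal, a question that pairs of cores differing in one place only could settle.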